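A few compounds are considered here, and "the series" means these few. Any claim that something is new, unique, unknown or untested is made for them only; others in the source may bear on it.

Compound 1 `OC[C@H]1O[C@@H](n2cnc3c(NCc4ccc(Cl)cc4)ncnc32)[C@H](O)[C@@H]1O` is the starting point. In a functional assay on CCRF-CEM cells (Homo sapiens) for antiproliferative activity, with a stated time of 72 h (a lower number here means a stronger inhibitor, a higher number a weaker inhibitor), compound 1 gives 10200 nM, the highest of the two numbers recorded. Compound 2 `COc1ccccc1CNc1ncnc2c1ncn2[C@@H]1O[C@H](CO)[C@@H](O)[C@H]1O` gives 3200 nM in this assay, so the step of a 3.2-fold lower number from compound 1 to compound 2 (0.50 log units; beyond the scatter) is a modest gain. Compound 3 `COc1ccc(CNc2ncnc3c2ncn3[C@@H]2O[C@H](CO)[C@@H](O)[C@H]2O)c(OC)c1` reaches only a limit in this assay, > 166000 nM. The step of an at least 16-fold higher number from compound 1 to compound 3 (1.21 log units; beyond the scatter) is a large loss, and the step of an at least 51-fold higher number from compound 2 to compound 3 (1.71 log units; beyond the scatter) is larger still, ending at the limit of > 166000 nM in this assay, at which 1 of the 3 values shown sits. Compound 4 `COc1cc(CNc2ncnc3c2ncn3[C@@H]2O[C@H](CO)[C@@H](O)[C@H]2O)cc(OC)c1` differs from compound 1 by 3,5-dimethoxyphenyl in place of 4-chlorophenyl on a saturated chain carbon bound to a nitrogen on an aromatic ring. The measured steps pull in opposite directions: one methoxy on the ring helped, while a second methoxy cost heavily. Since compound 4 carries two methoxy groups, the loss seen for compound 3 is the closer precedent, though its 3,5-dimethoxyphenyl differs from the 2,4-dimethoxyphenyl of compound 3, which leaves the size open. A weakening is therefore expected, a 3.9-fold higher number from compound 1 to compound 4 (0.59 log units; beyond the scatter). Compound 4 is estimated at 40000 nM, with a range from 8000 nM to 200000 nM.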

Compound 4, half-maximal inhibitory concentration: > 166000 nM
Compound 4: no number, only a limit; the forecaster's own chance of this, stated with the estimate: 30%; middle value at least 4.1-fold (0.61 log units) away from the limit.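

In this assay, the 3,5-dimethoxyphenyl group gives no recovery: the result is an at least 16-fold higher number from compound 1 to compound 4 (1.21 log units; beyond the scatter) and, measured against the single methoxy of the better compound, an at least 51-fold higher number from compound 2 to compound 4 (1.71 log units; beyond the scatter). The heavy loss seen with compound 3 is therefore not confined to the 2,4-dimethoxyphenyl group, since both dimethoxyphenyl compounds shown end at a limit rather than a number: the limit of > 166000 nM in this assay, at which 2 of the 4 values shown sit. The step from compound 3 to compound 4 cannot be read, as both values are limits, so these two groups cannot be ranked against each other.

Going by these compounds, it remains open whether the modest gain of compound 2 carries over to a different single group on the ring, such as a hydroxyl or an amine. Also open, on these data alone, is whether a ring bearing two chlorine atoms instead of two methoxy groups would meet the same loss.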